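Compound 3 to compound 4: changing the amine substituent

The compounds below may be only part of what the source reports. "The series", "measured", "known", "first", "only" and "open" are said of these compounds alone.

Measured in a functional assay on CWR22R cells (Homo sapiens) for antiproliferative activity, read by CCK-8 assay, with a stated time of 6 days; on this read-out lower numbers stand for stronger inhibition and higher numbers for weaker inhibition:
- Compound 1 `CC(=O)c1cc(C(=O)N[C@@H](C)Cn2ccc(-c3cc(F)c(C#N)c(Cl)c3)n2)n[nH]1`: > 30000 nM
- Compound 2 `CC(O)c1ccc(C(=O)N[C@@H](C)Cn2ccc(-c3ccc(C#N)c(Cl)c3)n2)cc1`: 9050 nM
- Compound 3 `C[C@@H](Cn1ccc(-c2ccc(C#N)c(Cl)c2)n1)Nc1cccnc1`: 21600 nM

Compound 1 reads > 30000 nM, which is a limit of the assay and not a number. Of the two true numbers, compound 3, at 21600 nM, is the higher. Compound 2, at 9050 nM, lies lower, and that gap is beyond the usual scatter.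

Compound 4 `Cc1ccnc(N[C@@H](C)Cn2ccc(-c3ccc(C#N)c(Cl)c3)n2)n1` carries 4-methylpyrimidin-2-yl in place of pyridin-3-yl on an amine nitrogen. Among the measured compounds shown here, no measured pair tests this change or any other single change. The expectation therefore rests on the level set by compound 3 at 21600 nM, and no shift beyond the scatter is expected. The expected step is a 1.4-fold lower number from compound 3 to compound 4 (0.13 log units; within the scatter). In this assay, the estimated value for compound 4 is 16000 nM, with an expected range of 6000 nM to 30000 nM.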

Compound 4, half-maximal inhibitory concentration: 4760 nM
Estimate against measurement, compound 4: 3.4-fold (0.53 log units) above, and the stated range ends above it.
By their numbers in this assay, from the lowest: compounds 4 and 2 (each within the scatter of the next); then compound 3. At a limit, above all of these: compound 1.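

Among the compounds shown here, on the amine nitrogen, 4-methylpyrimidin-2-yl in place of pyridin-3-yl gives the first single-change comparison: in this assay, the result is a 4.5-fold lower number from compound 3 to compound 4 (0.66 log units; beyond the scatter). For the compounds shown here, the read-out at this position therefore responds to the aromatic group on the amine nitrogen, which the earlier compounds, with no pair differing in one place, could not show. Compound 1 remains at a limit of the assay and not a number, and this step does not rest on it: the limit of > 30000 nM in this assay, at which 1 of the 4 values shown sits.

On these data alone, the added ring nitrogen and the methyl enter together, so their separate contributions to the step stay open. Also open, as far as these compounds go, is how an unsubstituted pyrimidin-2-yl, a trifluoromethyl in place of the methyl, or a saturated ring such as piperidine on the same amine nitrogen would read.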